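The compounds below may be only part of what the source reports. "The series", "measured", "known", "first", "only" and "open" are said of these compounds alone.

Series notes. Compounds sharing one core: compound 1 `CCCN(CCC)c1nc(C(C)(C)C)ccc1CNC(=O)C(C)c1ccc(NS(C)(=O)=O)c(F)c1`, compound 2 `CC(C(=O)NCc1ccc(C(C)(C)C)nc1N1CCCCCC1)c1ccc(NS(C)(=O)=O)c(F)c1` and compound 3 `CCOc1nc(C(C)(C)C)ccc1CNC(=O)C(C)c1ccc(NS(C)(=O)=O)c(F)c1`. In an assay on cells for antagonist activity at transient receptor potential cation channel subfamily V member 1 (Homo sapiens), read by FLIPR and calcium flux, with a stated time of 6 min (on this read-out lower numbers stand for stronger inhibition and higher numbers for weaker inhibition), compound 1 gives 2.5 nM, compound 2 gives 0.9 nM and compound 3 gives 14.8 nM. Compound 3 stands at the highest number of the three: the step of a 5.9-fold higher number from compound 1 to compound 3 (0.77 log units; beyond the scatter) and the step of a 16-fold higher number from compound 2 to compound 3 (1.22 log units; beyond the scatter) both run against it, while the step of a 2.8-fold lower number from compound 1 to compound 2 (0.44 log units; beyond the scatter) separates the two amine-bearing analogues. Next is compound 4 `CCCOc1nc(C(C)(C)C)ccc1CNC(=O)C(C)c1ccc(NS(C)(=O)=O)c(F)c1`, which differs from compound 3 by methyl in place of hydrogen on a saturated chain carbon, two bonds along the chain from an oxygen on an aromatic ring. Within the data shown here, none of the measured steps concerns a change of this kind; the three steps all exchange the whole group on the aromatic carbon, not the length of a chain on an ether oxygen. They show only that the position is sensitive, with the larger groups of compound 1 and compound 2 giving the lower numbers. A small downward step, or none beyond the scatter, is expected for compound 4 in this assay, a 1.6-fold lower number from compound 3 to compound 4 (0.22 log units; within the scatter). The estimate for compound 4 is 9 nM, ranging from 3 nM to 30 nM.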

Compound 4, inhibition constant: 1.7 nM
Compound 4: the middle estimate sits 5.3-fold (0.72 log units) above what was measured; the measured number lies below the stated range.
By their numbers in this assay, from the lowest: compounds 2, 4 and 1 (each within the scatter of the next, the first and the last beyond it); then compound 3.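

In this assay, among these compounds, the change from ethoxy to propoxy gives an 8.7-fold lower number from compound 3 to compound 4 (0.94 log units; beyond the scatter) and so shows that the length of the ether chain on this aromatic carbon matters, which no earlier step tested. The steps of a 1.9-fold higher number from compound 2 to compound 4 (0.28 log units; within the scatter) and a 1.5-fold lower number from compound 1 to compound 4 (0.17 log units; within the scatter) are both within the scatter, so among the compounds shown an ether on this carbon can match the azepan-1-yl and dipropylamino groups, and an amine is not required for a low number. The high number of compound 3 therefore goes with ethoxy in particular, not with an ether oxygen as such.

Going by these compounds, whether a butoxy chain, a branched isopropoxy group or a cyclopropylmethoxy group on the same carbon would extend, hold or reverse this step remains open. No evidence bearing on the size of the step from the added methyl is available here.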